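Amino for phenyl on the shared core

The source may hold more compounds than are shown below. What is called first, only, known or untested is meant among the compounds shown, and "the series" means these compounds.

Compound 2 `C#CCOc1ccc(-c2cc(-c3ccc(OCC#C)cc3)nc(-c3ccccc3)n2)cc1` gives 25600 nM in an assay on BTI-TN-5B1-4 cells for inhibition of Amine oxidase [flavin-containing] A (Homo sapiens), read by fluorescence and Amplex Red, using microsomes, with a stated time of 30 min; a higher number here means a weaker inhibitor, a lower number a stronger inhibitor. Compound 1 `C#CCOc1ccc(-c2cc(-c3ccccc3OCC#C)nc(-c3ccccc3)n2)cc1` gives 22000 nM in this assay, and the step of a 1.2-fold higher number from compound 1 to compound 2 (0.07 log units; within the scatter) is within the scatter. Compound 3 `C#CCOc1ccc(-c2cc(-c3ccc(OCC#C)cc3)nc(N)n2)cc1` carries amino in place of phenyl on an aromatic carbon. Among the measured compounds shown here, no measured step touches that position on the shared core; the only step in hand, a 1.2-fold higher number from compound 1 to compound 2 (0.07 log units; within the scatter), concerns a different group and offers no guide to size or direction here. Both measured values are weak, and the change exchanges a phenyl for an amino, so the expected step of a 1.4-fold higher number from compound 2 to compound 3 (0.14 log units; within the scatter) is a modest weakening at most, with wide uncertainty. Compound 3 is therefore estimated at 35000 nM, with an expected range from 10000 nM to 120000 nM.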

Compound 3, half-maximal inhibitory concentration: 32100 nM
Beside the measured number, compound 3's estimate is 1.1-fold (0.04 log units) above it, and the stated range covers the measured number.
By their numbers in this assay, from the lowest: compounds 1, 2 and 3 (each within the scatter of the next).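

Amino in place of phenyl on the aromatic carbon between two ring nitrogen atoms gives a 1.3-fold higher number from compound 2 to compound 3 (0.10 log units; within the scatter) in this assay. At this position, then, a change from phenyl to amino, which has no ring, leaves the number within the scatter. Nothing in hand speaks to the reason for this result.

Open, on these data alone, is whether a dimethylamino or morpholine group on this carbon would give a step beyond the scatter, in either direction.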